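Methoxy for hydrogen on the aryl ring: compound 3 to compound 4

The source may report more compounds than this note shows. Statements on the series, on what has been measured and on what is new or still open speak of the compounds shown alone.

Measured so far in a functional assay on MDA-MB-231 cells (Homo sapiens) for cytotoxicity, read by MTT assay; a lower number here means a stronger inhibitor, a higher number a weaker inhibitor:
- Compound 1 `COc1ccc(-n2cc(-c3cc(O)cc(O)c3)nn2)cc1O`: compound 1 gives > 10000 nM, which is a limit of the assay.
- Compound 2 `COc1cc(-n2cc(-c3cc(O)cc(O)c3)nn2)cc(OC)c1OC`: compound 2 gives > 10000 nM, a limit.
- Compound 3 `COc1ccc(-n2cc(-c3cc(O)cc(O)c3)nn2)cc1`: compound 3 gives > 10000 nM, a limit.

Compound 3 thus stands at the limit of this assay, not at a number, and every measured value of the shared core sits there as well (the limit of > 10000 nM in this assay, at which 3 of the 3 values shown sit). Among the measured compounds shown here, the one single-place step among the measured compounds, a step that the two limits leave unreadable from compound 1 to compound 3, is therefore unreadable: both ends are limits, so no size can be taken from it.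

The new compound is compound 4 `COc1ccc(-n2cc(-c3cc(O)cc(O)c3)nn2)cc1OC`. It differs from compound 3 by methoxy in place of hydrogen on an aromatic carbon. For the measured compounds named here, no measured step bears directly on this change; the step from compound 1 to compound 3, the only one available, gives no size. Compound 2, which also carries methoxy groups on the same ring, sits at the limit, and it shows nothing more.

With every neighbour at the limit, compound 4 is expected to return a limit too, with a central estimate of 20000 nM and a range from 8000 nM to 60000 nM. The step that the limit leaves unreadable from compound 3 to compound 4 is accordingly estimated as none beyond the scatter, against a limit.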

Compound 4, half-maximal inhibitory concentration: > 10000 nM
Compound 4 was reported as a limit; the forecaster's own chance of this, stated with the estimate: 85%; the middle value is on the limit's open side.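

No step to compound 4 from compound 1, compound 2 or compound 3 can be read, because both ends of each pair are limits and not numbers: the limit of > 10000 nM in this assay, at which 4 of the 4 values shown sit.

The compounds shown leave open whether any change on this aryl ring brings the shared core to a measurable value in this assay, and how large any difference among these four compounds is.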